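Ester series on a shared core: lipophilicity notes

A few compounds are considered here, and "the series" means these few. Any claim that something is new, unique, unknown or untested is made for them only; others in the source may bear on it.

Measured so far in a physicochemical assay for lipophilicity; on this read-out higher numbers stand for higher lipophilicity and lower numbers for lower lipophilicity:
compound 1 `C=CCc1ccc(OC(=O)c2ccc(C)cc2)c(OC)c1` gives 2.87
compound 2 `C=CCc1ccc(OC(=O)c2ccccc2Cl)c(OC)c1` gives 2.79
compound 3 `C=CCc1ccc(OC(=O)c2ccc(F)cc2)c(OC)c1` gives 2.7

Compound 1 holds the highest of the three numbers, but neither of the other two stands apart from it: the step of a number 0.08 log units lower from compound 1 to compound 2 (within the scatter) and the step of a number 0.17 log units lower from compound 1 to compound 3 (within the scatter) both lie within the scatter, as does the step of a number 0.09 log units lower from compound 2 to compound 3 (within the scatter). Across these three compounds the read-out is flat.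

Compound 4 `C=CCc1ccc(OC(=O)c2ccncc2)c(OC)c1` is not yet measured. It differs from compound 1 in one place: pyridin-4-yl in place of 4-methylphenyl on a carbonyl carbon.

Within the data shown here, none of the measured steps bears on this change directly. Each of them swaps one aryl group for another aryl group made of carbon only, or one substituent for another on such a ring, and each moved the number by less than the scatter. The change to compound 4 is of another kind: the entering group is a six-membered aromatic ring with one hetero atom and one hydrogen-bond acceptor, where the leaving group has none. Among the measured compounds shown here, no measured step brings in a hetero atom or an acceptor, so the flat steps seen so far do not carry over. A step clearly beyond the scatter is expected, downwards, with considerable uncertainty on its size.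

For compound 4 the estimate is 1.3, between 0.7 and 1.9. This estimate means a step of a number 1.57 log units lower from compound 1 to compound 4 (beyond the scatter).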

Compound 4, partition coefficient: 0.86
Estimate against measurement, compound 4: 0.44 log units above; low and high end bracket the measured number.
By their numbers in this assay, from the lowest: compound 4; then compounds 3, 2 and 1 (each within the scatter of the next).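

At this place, on a carbonyl carbon, the read-out in this assay is not flat for every aryl exchange: pyridin-4-yl in place of 4-methylphenyl gives a number 2.01 log units lower from compound 1 to compound 4 (beyond the scatter) (the large step in this set), in place of 4-fluorophenyl it gives a number 1.84 log units lower from compound 3 to compound 4 (beyond the scatter) and in place of 2-chlorophenyl it gives a number 1.93 log units lower from compound 2 to compound 4 (beyond the scatter) as well. All three steps are large and lie beyond the scatter, so among these four compounds only compound 4, the one compound with a ring holding a hetero atom and a hydrogen-bond acceptor, stands apart, while compounds 1, 2 and 3 stay within the scatter of one another. No measurement here accounts for the size of these steps.

As far as these compounds go, whether other entering groups at this carbonyl carbon, such as an amine or a carboxylic acid carried on the aryl ring, would move the read-out as far remains open. Also open, from the compounds shown here alone, is whether the exchange of 4-methylphenyl for pyridin-4-yl would give a step of similar size on a core bearing a longer chain.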